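A few compounds are considered here, and "the series" means these few. Any claim that something is new, unique, unknown or untested is made for them only; others in the source may bear on it.

Measured so far in a functional assay on the whole organism (strain Wistar) for inhibition, with Rattus norvegicus as the target, read by paw edema, with stated times of 1 h and 5 h, at a dose of 20 mg/kg by the oral route; on this read-out lower numbers stand for less inhibition and higher numbers for more inhibition at the one dose given (going by the name of the read-out):

Compound 1 `NS(=O)(=O)c1ccc2nc(N3N=C(c4ccc(Br)cc4)CC3c3ccc(Cl)cc3)sc2c1` gives 14%.
Compound 2 `NS(=O)(=O)c1ccc2nc(N3N=C(c4ccc(Br)cc4)CC3c3ccc(F)cc3)sc2c1` gives 14%.
Compound 3 `NS(=O)(=O)c1ccc2nc(N3N=C(c4ccc(Cl)cc4)CC3c3ccc(Cl)cc3)sc2c1` gives 14%.

All three share one core and differ only in the halogen on one phenyl ring. Compound 2 differs from compound 1 by fluoro in place of chloro on an aromatic carbon, and the step on that account was no change at the digits printed from compound 1 to compound 2 (within the scatter). The core of compound 3 differs from that of compound 1 by chloro in place of bromo on an aromatic carbon, and that step was no change at the digits printed from compound 1 to compound 3 (within the scatter).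

Compound 4 `NS(=O)(=O)c1ccc2nc(N3N=C(c4ccc(Cl)cc4)CC3c3ccc(F)cc3)sc2c1` has not yet been measured. It differs from compound 3 by fluoro in place of chloro on an aromatic carbon, the same change already seen from compound 1 to compound 2. For this assay the expected step is no change at the digits printed from compound 3 to compound 4 (within the scatter), a view resting on the earlier step of no change at the digits printed from compound 1 to compound 2 (within the scatter), which stayed within the scatter. Compound 4 is therefore estimated at 14%, expected to fall between 5% and 25%.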

Compound 4, a percentage reported as inhibition, in the whole organism at one dose (the size of the read-out at that dose, not a potency): 14%
Estimate against measurement, compound 4: no gap at the digits printed; the measured number falls inside the stated range.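

In this assay, fluoro in place of chloro gives no change at the digits printed from compound 3 to compound 4 (within the scatter), which matches the same swap on the other core: the same change on two cores in this assay, no change at the digits printed (within the scatter) from compound 1 to compound 2 and no change at the digits printed (within the scatter) from compound 3 to compound 4, 0 percentage points apart, within the scatter of two such steps. Chloro in place of bromo gives no change at the digits printed from compound 2 to compound 4 (within the scatter), and it too matches its earlier step: the same change on two cores in this assay, no change at the digits printed (within the scatter) from compound 1 to compound 3 and no change at the digits printed (within the scatter) from compound 2 to compound 4, 0 percentage points apart, within the scatter of two such steps. Within these four compounds, each halogen swap therefore carries over from one core to the other, but since no swap moved the result, this does not show that a swap with a real effect would carry over in the same way.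

The compounds shown leave open whether a group other than a halogen on these phenyl rings, such as a methoxy group, an amine or a carboxylic acid, would change the result in this assay.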